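A few compounds are considered here, and "the series" means these few. Any claim that something is new, unique, unknown or untested is made for them only; others in the source may bear on it.

The three measured compounds and their numbers in an assay on HEK293 cells for displacement of a labelled ligand from NPC1-like intracellular cholesterol transporter 1 (Homo sapiens) (a higher number here means a weaker inhibitor, a lower number a stronger inhibitor), are:

Compound 1 `CC(C)(C)OC(=O)NC1CCN(C(=O)CN2CN(c3ccccc3)C3(CCN(C(=O)c4ccc(C(C)(C)C)cc4)CC3)C2=O)CC1`: 8300 nM
Compound 2 `CC(C)(C)c1ccc(C(=O)N2CCC3(CC2)C(=O)N(CC(=O)NCCCN)CN3c2ccccc2)cc1`: 4200 nM
Compound 3 `CC(C)(C)OC(=O)N1CCN(C(=O)CN2CN(c3ccccc3)C3(CCN(C(=O)c4ccc(C5CCCCC5)cc4)CC3)C2=O)CC1`: 3500 nM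

Among these three numbers compound 2 holds the second highest. Its nearest neighbour is compound 3 and its furthest is compound 1, yet both gaps lie within the scatter, so no order among the three can be read from them.

Compound 4 `CCOC(=O)C1CCCN(C(=O)CN2CN(c3ccccc3)C3(CCN(C(=O)c4ccc(C(C)(C)C)cc4)CC3)C2=O)C1` differs from compound 2 in one place: 3-(ethoxycarbonyl)piperidin-1-yl in place of (3-aminopropyl)amino on a carbonyl carbon. Among the compounds with values here, no measured pair shows such a change, and the three known numbers sit close together, so no step beyond the scatter is expected in this assay in either direction. For compound 4 the estimate is 6000 nM, between 2500 nM and 15000 nM. The step of a 1.4-fold higher number from compound 2 to compound 4 (0.15 log units; within the scatter) is accordingly expected to be essentially flat.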

Compound 4, half-maximal inhibitory concentration: 8200 nM
Estimate against measurement, compound 4: 1.4-fold (0.14 log units) below; low and high end bracket the measured number.
By their numbers in this assay, from the lowest: compounds 3, 2, 4 and 1 (each within the scatter of the next, the first and the last beyond it).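

In this assay, putting 3-(ethoxycarbonyl)piperidin-1-yl in place of (3-aminopropyl)amino on the carbonyl carbon gives a 2.0-fold higher number from compound 2 to compound 4 (0.29 log units; within the scatter). Within the data shown here, this position therefore accepts a group with more heavy atoms, a six-membered ring and no hydrogen-bond donors, with no step that can be read from the scatter. No measurement shown accounts for this result. As far as these compounds go, what remains open is whether a carboxylic acid in place of the ethoxycarbonyl, or a longer chain ending in an amine, would move the number beyond the scatter.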